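Three Limits and an Unmeasured Fourth Compound

This account rests on a few compounds, and the source may have more. Where it says the series, first, only, none or still open, it means among the compounds named here.

Compound 1 `O=C(CN1CCCCC1)Nc1ccc2ncnc(Nc3cccc(C(F)(F)F)c3)c2c1` is examined in a functional assay on MCF7 cells (Homo sapiens) for antiproliferative activity, read by MTT assay, with a stated time of 48 h; a higher number here means a weaker inhibitor, a lower number a stronger inhibitor. In this assay compound 1 gives > 100000 nM, which is a limit of the assay and not a number. Compound 2 `CN1CCN(CC(=O)Nc2ccc3ncnc(Nc4cccc(C(F)(F)F)c4)c3c2)CC1` carries the change (4-methylpiperazin-1-yl in place of piperidin-1-yl on a saturated chain carbon bound to a carbonyl carbon). In this assay compound 2 gives > 100000 nM, again only a limit. The step that the two limits leave unreadable from compound 1 to compound 2 therefore cannot be read. Compound 3 `O=C(CN1CCCCC1)Nc1ccc2ncnc(Nc3ccc(Cl)c(C(F)(F)F)c3)c2c1` differs from compound 1 by chloro in place of hydrogen on an aromatic carbon. In this assay compound 3 gives > 100000 nM, a limit as well. The step that the two limits leave unreadable from compound 1 to compound 3 is likewise unreadable, since every value shown sits at the limit of > 100000 nM in this assay, at which 3 of the 3 values shown sit. Compound 4 `CN1CCN(CC(=O)Nc2ccc3ncnc(Nc4ccc(Cl)c(C(F)(F)F)c4)c3c2)CC1` stands to compound 3 as compound 2 stands to compound 1, the same change at the same place: 4-methylpiperazin-1-yl in place of piperidin-1-yl on a saturated chain carbon bound to a carbonyl carbon. The step is expected to be a step that the limit leaves unreadable from compound 3 to compound 4 because compound 1 and compound 2 both sit at the limit of > 100000 nM in this assay, at which 3 of the 3 values shown sit. Compound 4 is expected to give 150000 nM in this assay, with a range from 50000 nM to 500000 nM.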

Compound 4, half-maximal inhibitory concentration: > 100000 nM
Compound 4 ended at the assay's limit; the forecaster's own chance of this, stated with the estimate: 90%; the middle value is on the limit's open side.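

Compound 4 also gives only a limit, so neither step to it, from compound 3 or from compound 2, can be read: the limit of > 100000 nM in this assay, at which 4 of the 4 values shown sit.

The compounds shown leave open how strongly any of the four inhibits, and whether either change alters that.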